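The source may hold more compounds than are shown below. What is called first, only, known or untested is meant among the compounds shown, and "the series" means these compounds.

Compound 2, with the structure `CC(C)(C)CNC(=O)C[C@H](NC(=O)CCc1ccccc1)C(=O)N[C@@H](CCc1ccccc1)C(=O)NCc1ccccc1Cl`, gives 18 nM in an assay on HEK293 cells for inhibition of nuclear factor NF-kappa-B complex (Homo sapiens), read by a luciferase reporter, with stated times of 1 h and 3 h (on this read-out lower numbers stand for stronger inhibition and higher numbers for weaker inhibition), the lowest of the two numbers measured here; compound 1, with the structure `CC(C)(C)CNC(=O)C[C@H](NC(=O)CCc1ccccc1)C(=O)N[C@@H](CCc1ccccc1)C(=O)NCC1CC1`, gives 38 nM. Going by the values given here, the one step known so far, a 2.1-fold lower number from compound 1 to compound 2 (0.32 log units; beyond the scatter), concerns the group on the saturated chain carbon bound to an amide-type nitrogen. Compound 3, with the structure `Cc1cc(C(=O)N[C@@H](CC(=O)NCC(C)(C)C)C(=O)N[C@@H](CCc2ccccc2)C(=O)NCc2ccccc2Cl)no1`, is not yet measured, and it differs from compound 2 elsewhere: 5-methyl-1,2-oxazol-3-yl in place of phenethyl on a carbonyl carbon. Among the compounds with values here, no measured step touches this carbonyl end of the shared core, so the one known step gives no guide in either direction, and the change is more than a small one. The expectation for compound 3 therefore rests on compound 2 alone and is stated as roughly no change beyond the scatter, a 2.2-fold higher number from compound 2 to compound 3 (0.35 log units; beyond the scatter), with wide uncertainty. On that basis compound 3 is estimated at 40 nM, within 8 nM to 200 nM.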

Compound 3, half-maximal inhibitory concentration: 9 nM
Compound 3: the middle estimate sits 4.4-fold (0.65 log units) above what was measured; measured number inside the range.
By their numbers in this assay, from the lowest: compounds 3 and 2 (each within the scatter of the next); then compound 1.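

In this assay, putting 5-methyl-1,2-oxazol-3-yl in place of phenethyl on the carbonyl carbon gives a result within the scatter (a 2.0-fold lower number from compound 2 to compound 3 (0.30 log units; within the scatter)), so this read-out does not separate the two groups. The earlier step did not touch this end of the molecule; this one shows that a five-membered aromatic ring with 2 hetero atoms and 2 hydrogen-bond acceptors can stand here in place of phenethyl, with its six-membered carbon ring, and the number stays within the scatter. Nothing available explains why the two groups read alike.

From the compounds shown here alone, whether a carboxylic acid, an amine or a longer chain ending in a phenyl ring would also read alike at this carbonyl carbon remains open. Also open, going by these compounds, is whether the same swap would behave this way with the cyclopropyl group of compound 1 in place of the 2-chlorophenyl group.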